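The compounds below may be only part of what the source reports. "The series", "measured", "known", "first", "only" and "open" are said of these compounds alone.

Measured compounds:
- compound 1 `Cc1ccc(C(=O)Nc2cccc(-c3oc4cc(-c5ccc(F)cc5)ccc4c(=O)c3O)c2)cc1`: 12900 nM
- compound 2 `O=C(Nc1cccc(-c2oc3cc(-c4ccc(F)cc4)ccc3c(=O)c2O)c1)c1ccc(F)cc1F`: 9640 nM
- compound 3 `COc1ccccc1C(=O)Nc1cccc(-c2oc3cc(-c4ccc(F)cc4)ccc3c(=O)c2O)c1`: 6370 nM

In a functional assay on GTL 16 cells for antiproliferative activity against GTL 16 cell line (Homo sapiens), read by CCK-8 assay, with a stated time of 72 h (a lower number here means a stronger inhibitor, a higher number a weaker inhibitor), compound 3 gives the lowest of the three numbers. Its nearest neighbour is compound 2, and the gap a 1.5-fold lower number from compound 2 to compound 3 (0.18 log units; within the scatter) lies within the scatter, so the two cannot be ordered. Against compound 1 the step of a 2.0-fold lower number from compound 1 to compound 3 (0.31 log units; beyond the scatter) is modest but beyond the scatter. Compound 1 and compound 2 differ by a 1.3-fold lower number from compound 1 to compound 2 (0.13 log units; within the scatter), which is within the scatter.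

Compound 4 `O=C(Nc1cccc(-c2oc3cc(-c4ccc(F)cc4)ccc3c(=O)c2O)c1)c1cccc(F)c1` is obtained from compound 3 by the change (3-fluorophenyl in place of 2-methoxyphenyl on a carbonyl carbon). The bearing steps are those that lead into compound 3: the 2-methoxyphenyl amide stands somewhat lower than either the 4-methylphenyl or the 2,4-difluorophenyl amide, and the two fluorinated and methylated analogues sit close together. Returning to a fluorinated aryl amide is therefore expected to give a number near those of compound 1 and compound 2, a mild rise from compound 3 of about a 1.5-fold higher number from compound 3 to compound 4 (0.17 log units; within the scatter). Compound 4 is estimated at 9500 nM, with a range from 5000 nM to 19000 nM.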

Compound 4, half-maximal inhibitory concentration: 15800 nM
The estimate for compound 4 lay 1.7-fold (0.22 log units) below the measured number, and the stated range covers the measured number.
By their numbers in this assay, from the lowest: compounds 3, 2, 1 and 4 (each within the scatter of the next, the first and the last beyond it).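

In this assay, replacing the 2-methoxyphenyl group on the carbonyl carbon with 3-fluorophenyl gives a 2.5-fold higher number from compound 3 to compound 4 (0.39 log units; beyond the scatter), so the 2-methoxyphenyl amide now stands apart from two of the other three amides, though compound 2 still cannot be separated from compound 3. The remaining steps, a 1.6-fold higher number from compound 2 to compound 4 (0.21 log units; within the scatter) and a 1.2-fold higher number from compound 1 to compound 4 (0.09 log units; within the scatter), both lie within the scatter, so the 3-fluorophenyl, 2,4-difluorophenyl and 4-methylphenyl amides cannot be ordered among themselves. Nothing available here explains the difference between the 2-methoxyphenyl and 3-fluorophenyl amides.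

The compounds shown leave open whether the advantage of compound 3 belongs to the methoxy oxygen or to where the group sits, which a 4-methoxyphenyl or 2-fluorophenyl amide would help to separate. They also leave open how an aryl ring carrying an amine or a carboxylic acid would behave at this position.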